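The compounds below may be only part of what the source reports. "The series", "measured", "known", "first", "only" and "open" are said of these compounds alone.

Of the compounds shown here, three sharing one core have been tested in an ADME assay on L02 cells (Homo sapiens) for cytotoxicity, read by MTT assay, with a stated time of 72 h; on this read-out lower numbers stand for stronger inhibition and higher numbers for weaker inhibition. Compound 1 (`CC/C=C/C(=O)Nc1cccc(Oc2nc(Nc3ccn(C)n3)nc3c2CSCC3)c1`) gives > 50000 nM, which is a limit of the assay and not a number. Compound 2 (`C=CC(=O)Nc1cccc(Oc2nc(Nc3cccc(OC)c3)nc3c2CSCC3)c1`) gives 48900 nM, a measured value. Compound 3 (`CC/C=C/C(=O)Nc1cccc(Oc2nc(Nc3cccc(OC)c3)nc3c2CSCC3)c1`) gives > 50000 nM, which is also only a limit. From the compounds shown here alone, compound 3 therefore sits on (the limit of > 50000 nM in this assay, at which 2 of the 3 values shown sit), so its true position is unknown.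

Compound 4 (`COc1cccc(Nc2nc3c(c(Oc4cccc(NC(=O)/C=C/C(C)C)c4)n2)CSCC3)c1`) departs from compound 3 by a single change: methyl in place of hydrogen on a saturated chain carbon bound to a double-bonded chain carbon and a saturated chain carbon. This is methyl in place of hydrogen on a saturated chain carbon bound to a double-bonded chain carbon and a saturated chain carbon, which turns but-1-en-1-yl into 3-methylbut-1-en-1-yl.

The nearest evidence is a change in the same group, an at least 1.0-fold higher number from compound 2 to compound 3 (0.00 log units; that floor lies within the scatter), and this step gives only a floor. The other measured change, a step that the two limits leave unreadable from compound 1 to compound 3, concerns the group on the nitrogen and gives no usable size. Neither step points to a shift beyond the scatter in this assay, so none is expected here. The expected step is a step that the limit leaves unreadable from compound 3 to compound 4, and it is likely to be obscured by the limit. The estimate for compound 4 is 55000 nM, with an expected range of 30000 nM to 100000 nM.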

Compound 4, half-maximal inhibitory concentration: > 50000 nM
Compound 4: a limit, no number (the forecaster's own chance of this, stated with the estimate: 80%); the middle value lies beyond the limit too.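

The step from compound 3 to compound 4 cannot be read in this assay, because both compounds stand at the same limit: the limit of > 50000 nM in this assay, at which 3 of the 4 values shown sit.

Set against the vinyl group of compound 2, the 3-methylbut-1-en-1-yl group gives an at least 1.0-fold higher number from compound 2 to compound 4 (0.00 log units; that floor lies within the scatter). This is only a floor, so it shows no shift beyond the scatter but does not rule one out. What compound 4 adds is that the isopropyl end, like the ethyl end in compound 3, does not bring the number in this assay down to a measured value, so a second group on the carbonyl carbon now ends in a limit.

From the compounds shown here alone, how far compound 3 and compound 4 lie past that limit stays open, and so does any order between them. Going by these compounds, it is also open whether an amine at the end of the chain, or a longer chain, on the same carbonyl carbon would give a measured value in this assay.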